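Exchanging 1H-1,2,3-triazol-1-yl for 1,3-thiazol-2-yl on the aromatic carbon

The compounds below may be only part of what the source reports. "The series", "measured", "known", "first", "only" and "open" are said of these compounds alone.

Three compounds share one core. Compound 1 `O=C(O)c1cc(-c2csnn2)ccc1O` carries 1,2,3-thiadiazol-4-yl on it; in a functional assay on the whole organism for inhibition, with Rattus norvegicus as the target, read by paw edema (a lower number here means that less compound is needed, a higher number that more compound is needed for the effect), compound 1 reaches only a limit of the assay, > 200 mg/kg. Compound 2 `O=C(O)c1cc(-n2ccnn2)ccc1O` gives 150 mg/kg in this assay and compound 3 `O=C(O)c1cc(-c2cocn2)ccc1O` gives 110 mg/kg. Among these two numbers compound 2 stands with a 1.4-fold lower number from compound 2 to compound 3 (0.13 log units; within the scatter), so the pair cannot be told apart. Two further measured steps bear on the question: an at least 1.3-fold lower number from compound 1 to compound 2 (0.12 log units; that floor lies within the scatter) and an at least 1.8-fold lower number from compound 1 to compound 3 (0.25 log units; that floor lies within the scatter). Compound 4 `O=C(O)c1cc(-c2nccs2)ccc1O` differs from compound 2 in one place: 1,3-thiazol-2-yl in place of 1H-1,2,3-triazol-1-yl on an aromatic carbon. Every measured exchange of the five-membered ring stayed within the scatter, and the expected step is therefore a 1.3-fold lower number from compound 2 to compound 4 (0.10 log units; within the scatter). Compound 4 is accordingly estimated at 120 mg/kg, between 60 mg/kg and 240 mg/kg.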

Compound 4, dose for half-maximal effect: > 250 mg/kg
Compound 4 gave a limit, no number; the forecaster's own chance of this, stated with the estimate: 25%; middle value at least 2.0-fold (0.31 log units) from the limit.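

Compound 4 stands at a limit of this assay, not at a number: the limit of > 250 mg/kg in this assay, at which 1 of the 4 values shown sits.

Exchanging 1,3-oxazol-4-yl for 1,3-thiazol-2-yl gives an at least 2.2-fold higher number from compound 3 to compound 4 (0.35 log units; beyond the scatter), so at this position, para to a hydroxy group, the five-membered rings shown are not all interchangeable. Exchanging 1H-1,2,3-triazol-1-yl for the same group gives an at least 1.6-fold higher number from compound 2 to compound 4 (0.22 log units; that floor lies within the scatter), and the step between the two limits, from the thiadiazole of compound 1, cannot be read.

Going by these compounds, how large the true steps to compound 4 are stays open. So does how a phenyl ring or an aminomethyl group on the same carbon would read in this assay.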